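The compounds below may be only part of what the source reports. "The series", "measured", "known", "first", "only" and "open" are said of these compounds alone.

In a functional assay on HEK293 cells for agonist activity at D(4) dopamine receptor (Homo sapiens), read by FLIPR (on this read-out lower numbers stand for smaller maximal responses and higher numbers for larger maximal responses), compound 1 `O=C(NCN1CCC(c2cccc[n+]2[O-])CC1)c1cnccc1Cl` gives 44%, the lower of the two numbers at hand. Compound 2 `Cc1cc(F)ccc1NC(=O)CN1CCC(c2cccc[n+]2[O-])CC1` gives 84% in this assay, a number beyond the scatter above compound 1. Compound 3 `O=C(NCN1CCC(c2cccc[n+]2[O-])CC1)c1ccccn1` has not yet been measured in this assay; it differs from compound 1 in one place: pyridin-2-yl in place of 4-chloropyridin-3-yl on a carbonyl carbon. Among the measured compounds shown here, no single-change step between measured compounds exists to set a scale, so the expected step is small, with no clear direction beyond the scatter, as a number 6 percentage points higher from compound 1 to compound 3 (within the scatter). Compound 3 is accordingly estimated to give 50% in this assay, within a range from 25% to 80%.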

Compound 3, largest response reached (reported as efficacy), in percent of the reference or control that the assay uses: 40%
For compound 3 the middle estimate is 10 percentage points above the measured one; measured number inside the range.
By their numbers in this assay, from the lowest: compounds 3 and 1 (each within the scatter of the next); then compound 2.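

Among the compounds shown here, replacing 4-chloropyridin-3-yl with pyridin-2-yl on a carbonyl carbon gives the first single-change step in this assay, a number 4 percentage points lower from compound 1 to compound 3 (within the scatter), where the earlier compounds offered none. At this position, therefore, the read-out does not separate these two rings, with or without the chlorine. No available evidence bears on this result.

Going by these compounds, it remains open whether an amine, a carboxylic acid or a longer chain on this carbonyl carbon would give a step beyond the scatter.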